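A few compounds are considered here, and "the series" means these few. Any claim that something is new, unique, unknown or untested is made for them only; others in the source may bear on it.

Measured compounds:
compound 1 `COc1c(OC(C)C)cc2occ(-c3csc4ccccc34)c(=O)c2c1O` — > 10000 nM
compound 2 `COc1c(O)cc2occ(-c3csc4ccccc34)c(=O)c2c1O` — > 10000 nM
compound 3 `COc1c(OC(C)C)cc2c(c1OC(C)C)C(=O)/C(=C/c1csc3ccccc13)O2` — > 10000 nM

All three values come from a functional assay on KB cells (Homo sapiens) for antiproliferative activity, read by sulforhodamine B assay, with a stated time of 72 h; on this read-out higher numbers stand for weaker inhibition and lower numbers for stronger inhibition. Each of them is a limit of this assay and not a number; the limit of > 10000 nM in this assay, at which 3 of the 3 values shown sit, covers every value shown. Compound 1 gives a limit, > 10000 nM. Compound 2 gives a limit, > 10000 nM. Compound 3 gives a limit, > 10000 nM. The change from compound 1 to compound 2 is hydrogen in place of isopropyl on an oxygen on an aromatic ring, and the resulting step is a step that the two limits leave unreadable from compound 1 to compound 2. Compound 4 `COc1c(OC(C)C)cc2c(c1O)C(=O)/C(=C/c1csc3ccccc13)O2` is not yet measured in this assay; it differs from compound 3 by hydrogen in place of isopropyl on an oxygen on an aromatic ring, which is the same change at the same place. The difference between the core of compound 1 and the core of compound 3 is not broken down here. The expected step is a step that the limit leaves unreadable from compound 3 to compound 4, which rests on the limit of compound 3, > 10000 nM, and on the unreadable step that the two limits leave unreadable from compound 1 to compound 2. Compound 4 is expected at 20000 nM, between 8000 nM and 60000 nM, most likely reported only as a limit.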

Compound 4, half-maximal inhibitory concentration: > 10000 nM
Compound 4: no number, only a limit; the forecaster's own chance of this, stated with the estimate: 85%; the middle value does not contradict the limit.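

Compound 3 and compound 4 each give only a limit, so no step can be read between them: the limit of > 10000 nM in this assay, at which 4 of the 4 values shown sit. The compounds shown leave open what number any of them would give, and whether the isopropoxy to hydroxy change shifts activity on either core.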